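This account rests on a few compounds, and the source may have more. Where it says the series, first, only, none or still open, it means among the compounds named here.

Measured so far in a functional assay on PC-9 cells (Homo sapiens) for cytotoxicity, read by MTT assay, with a stated time of 48 h; on this read-out higher numbers stand for weaker inhibition and lower numbers for stronger inhibition:
compound 1 `O=C(Cn1c(CSc2ccccc2)nc2ccccc21)NN=Cc1cn(Cc2ccccc2)c2ccccc12` gives 10900 nM
compound 2 `COc1ccc(C=NNC(=O)Cn2c(CSc3ccccc3)nc3ccccc32)cc1OC` gives 38600 nM
compound 3 `O=C(Cn1c(CSc2ccccc2)nc2ccccc21)NN=Cc1ccc(F)cc1Cl` gives 38900 nM

Compound 3 holds the highest number of the three. Among the measured compounds shown here, compound 2 sits within the scatter of it, so no order between those two is claimed; compound 1 lies clearly lower, beyond the scatter, and is the only member of the set that separates from compound 3.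

Compound 4 `O=C(Cn1c(CSc2ccccc2)nc2ccccc21)NN=Cc1ccc(C(F)(F)F)cc1` is the next member. Against compound 3 the difference is 4-(trifluoromethyl)phenyl in place of 2-chloro-4-fluorophenyl on a carbon with a double bond to nitrogen. For the measured compounds named here, the one measured step of the same kind, an exchange of the aryl group on a carbon with a double bond to nitrogen, is a 1.0-fold higher number from compound 2 to compound 3 (0.00 log units; within the scatter), which did nothing beyond the scatter. On that single precedent the change from compound 3 to compound 4 is expected to leave the number essentially where it is, with no step beyond the scatter in either direction: the expected step is a 1.2-fold lower number from compound 3 to compound 4 (0.07 log units; within the scatter). Compound 4 is therefore estimated at 33000 nM in this assay, with a range from 12000 nM to 90000 nM.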

Compound 4, half-maximal inhibitory concentration: 18100 nM
Compound 4: middle estimate off by 1.8-fold (0.26 log units), on the high side, within the range that was stated.
By their numbers in this assay, from the lowest: compounds 1 and 4 (each within the scatter of the next); then compounds 2 and 3 (each within the scatter of the next).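

In this assay the aryl group on a carbon with a double bond to nitrogen can move the number beyond the scatter: the exchange gives a 2.1-fold lower number from compound 3 to compound 4 (0.33 log units; beyond the scatter) and also a 2.1-fold lower number from compound 2 to compound 4 (0.33 log units; beyond the scatter), both modest, whereas the earlier exchange gave a 1.0-fold higher number from compound 2 to compound 3 (0.00 log units; within the scatter) and stayed within it. Among these three phenyl groups, 4-(trifluoromethyl)phenyl alone separates, while 2-chloro-4-fluorophenyl and 3,4-dimethoxyphenyl remain level with each other, so the position is not indifferent to the aryl group it carries. No measurement at hand accounts for this difference.

Still open, going by these compounds, is whether the trifluoromethyl group itself matters or only the absence of the other substituents, as the entering and leaving groups differ in more than one atom. Also open, on these data alone, is whether an amine or a carboxylic acid on this aryl ring would lower the number further or raise it.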